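Three Amides on a Shared Core, and a Fourth to Come

A few compounds are considered here, and "the series" means these few. Any claim that something is new, unique, unknown or untested is made for them only; others in the source may bear on it.

Three compounds share one core and differ only in the aryl group attached to the amide carbonyl. Compound 1 `O=C(Nc1ccc(Cl)c(-c2nnc3c(Cl)cccn23)c1)c1cccc(Cl)c1` gives 71900 nM in a functional assay on MCF7 cells (Homo sapiens) for antiproliferative activity, read by MTT assay, with a stated time of 72 h; a higher number here means a weaker inhibitor, a lower number a stronger inhibitor. Compound 2 `CS(=O)(=O)c1ccc(C(=O)Nc2ccc(Cl)c(-c3nnc4c(Cl)cccn34)c2)cc1` gives 94200 nM in this assay, and compound 3 `CS(=O)(=O)c1cccc(C(=O)Nc2ccc(Cl)c(-c3nnc4c(Cl)cccn34)c2)c1` gives 88900 nM. Among these three numbers compound 3 stands second highest, yet its neighbours are close: a 1.1-fold lower number from compound 2 to compound 3 (0.03 log units; within the scatter), and a 1.2-fold higher number from compound 1 to compound 3 (0.09 log units; within the scatter). The remaining step, a 1.3-fold higher number from compound 1 to compound 2 (0.12 log units; within the scatter), is also small. None of the three amides can be called stronger or weaker than another.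

Compound 4 `O=C(Nc1ccc(Cl)c(-c2nnc3c(Cl)cccn23)c1)c1ccccc1Cl` carries the change (2-chlorophenyl in place of 3-(methylsulfonyl)phenyl on a carbonyl carbon). Every measured swap of the aryl group on the carbonyl carbon, whether chloro for methylsulfonyl or one ring position for another, has left the number within the scatter, so the expectation for this assay is a step of about a 1.1-fold lower number from compound 3 to compound 4 (0.05 log units; within the scatter), in no particular direction. Compound 4 is therefore estimated at 80000 nM, with a likely range from 30000 nM to 200000 nM.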

Compound 4, half-maximal inhibitory concentration: 92200 nM
Beside the measured number, compound 4's estimate is 1.2-fold (0.06 log units) below it, and the stated range covers the measured number.
By their numbers in this assay, from the lowest: compounds 1, 3, 4 and 2 (each within the scatter of the next).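

The 2-chlorophenyl group brings a new substitution pattern to the aryl ring on the carbonyl carbon, yet it cannot be told apart from any of the earlier groups in this assay. That holds against 3-(methylsulfonyl)phenyl (a 1.0-fold higher number from compound 3 to compound 4 (0.02 log units; within the scatter)), against 4-(methylsulfonyl)phenyl (a 1.0-fold lower number from compound 2 to compound 4 (0.01 log units; within the scatter)) and against 3-chlorophenyl (a 1.3-fold higher number from compound 1 to compound 4 (0.11 log units; within the scatter)), so among these four compounds neither the choice of chloro or methylsulfonyl nor the ring position tried separates one amide from another. No supporting measurement is available to explain why these aryl groups give such similar numbers.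

Still open, from the compounds shown here alone, is whether an amine or a carboxylic acid on this ring, or a longer chain in place of the ring, would give a step beyond the scatter. Also open, going by these compounds, is whether any change away from the carbonyl carbon, on the shared core, would move the number at all.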